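Swapping the ring on the ether oxygen

This account rests on a few compounds, and the source may have more. Where it says the series, first, only, none or still open, it means among the compounds named here.

compound 1 `COc1ccc(Oc2ccccc2NC(C)=C2C(=O)CC(c3ccccc3)CC2=O)cc1OC`: 65 nM
compound 2 `COc1cc(Oc2ccccc2NC(C)=C2C(=O)CC(c3ccccc3)CC2=O)ccc1N`: 26 nM
compound 3 `CCOc1ccccc1NC(C)=C1C(=O)CC(c2ccccc2)CC1=O`: 190 nM

These numbers come from a functional assay on L1210 cells (Mus musculus) for antiproliferative activity, read by cell counting, with a stated time of 96 h; on this read-out lower numbers stand for stronger inhibition and higher numbers for weaker inhibition. Of the three, compound 1 holds the middle place at 65 nM, with compound 2 lower and compound 3 higher.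

The next compound, compound 4 `CC(Nc1ccccc1Oc1cccc(N)c1)=C1C(=O)CC(c2ccccc2)CC1=O`, has not yet been measured. It keeps the core of compound 1 and changes one group: 3-aminophenyl in place of 3,4-dimethoxyphenyl on an oxygen on an aromatic ring. In words, this is 3-aminophenyl in place of 3,4-dimethoxyphenyl on an oxygen on an aromatic ring.

The closest guide is a 2.5-fold lower number from compound 1 to compound 2 (0.40 log units; beyond the scatter), a modest step that came with amino in place of methoxy on an aromatic carbon. Among the measured compounds shown here, the match is only partial, since 3-aminophenyl carries no methoxy and no measured compound has this exact ring. Two further steps replace the whole ring with ethyl: a 2.9-fold higher number from compound 1 to compound 3 (0.47 log units; beyond the scatter) and a 7.3-fold higher number from compound 2 to compound 3 (0.86 log units; beyond the scatter). Both show that the number moves with this group, but neither shows how a different ring would behave.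

A small move toward a lower number is therefore expected, and it may not clear the scatter. The expected change is a 1.6-fold lower number from compound 1 to compound 4 (0.21 log units; within the scatter). For compound 4 the estimated value is 40 nM, with an expected range from 15 nM to 110 nM.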

Compound 4, half-maximal inhibitory concentration: 53 nM
Compound 4: the middle estimate sits 1.3-fold (0.12 log units) below what was measured; measured number inside the range.
By their numbers in this assay, from the lowest: compound 2; then compounds 4 and 1 (each within the scatter of the next); then compound 3.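

In this assay, the 3-aminophenyl ring serves as well as the 3,4-dimethoxyphenyl ring, with a 1.2-fold lower number from compound 1 to compound 4 (0.09 log units; within the scatter) and so neither methoxy group is needed for a number in this range. A second ring on this oxygen also gains a further example, with a 3.6-fold lower number from compound 3 to compound 4 (0.55 log units; beyond the scatter) when 3-aminophenyl takes the place of ethyl, and compounds 1, 2 and 4 all give lower numbers than the ethyl compound 3. Compound 2 keeps the lowest number, with a 2.0-fold higher number from compound 2 to compound 4 (0.31 log units; beyond the scatter) on going to 3-aminophenyl, but that single step both removes the methoxy and changes where the amino group sits, so it cannot separate the two changes.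

The compounds shown do not tell how an unsubstituted phenyl or a 4-aminophenyl ring on this oxygen would compare, which leaves the separate shares of the amino and methoxy groups open. Nothing measured here explains why these rings give the numbers they do.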